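The source may report more compounds than this note shows. Statements on the series, on what has been measured and on what is new or still open speak of the compounds shown alone.

Measured compounds:
compound 1, `CNC(=O)c1cc(C)n(Cc2cc(Cl)ccc2OCc2ccccc2)n1`, 100 nM
compound 2, `Cc1cc(C(=O)Nc2ccccc2)nn1Cc1cc(Cl)ccc1OCc1ccccc1`, 39.8 nM
compound 3, `Cc1cc(C(=O)NCc2ccccn2)nn1Cc1cc(Cl)ccc1OCc1ccccc1`, 25.1 nM

All three share one core and were tested in an assay on CHO-K1 cells for displacement of a labelled ligand from prostaglandin E2 receptor EP1 subtype (Homo sapiens); a higher number here means a weaker inhibitor, a lower number a stronger inhibitor. Compound 2 gives the second highest of the three numbers. The step of a 1.6-fold lower number from compound 2 to compound 3 (0.20 log units; within the scatter) lies within the scatter, whereas a 2.5-fold lower number from compound 1 to compound 2 (0.40 log units; beyond the scatter) lies beyond it, as does a 4.0-fold lower number from compound 1 to compound 3 (0.60 log units; beyond the scatter).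

Compound 4, `Cc1cc(C(=O)NCc2cccnc2)nn1Cc1cc(Cl)ccc1OCc1ccccc1`, has not yet been measured. It differs from compound 2 by (pyridin-3-yl)methyl in place of phenyl on an amide-type nitrogen. The closest guide is the step of a 1.6-fold lower number from compound 2 to compound 3 (0.20 log units; within the scatter), in which a (pyridin-2-yl)methyl group likewise replaced phenyl on the same nitrogen and produced no change beyond the scatter. The larger steps of a 2.5-fold lower number from compound 1 to compound 2 (0.40 log units; beyond the scatter) and a 4.0-fold lower number from compound 1 to compound 3 (0.60 log units; beyond the scatter) show that enlarging the methyl amide helps, but both phenyl and pyridinylmethyl variants land close together. Compound 4 is therefore expected to sit near compound 2, with a step of a 1.2-fold lower number from compound 2 to compound 4 (0.09 log units; within the scatter) that is expected to stay within the scatter. The estimate for compound 4 in this assay is 32 nM, expected to fall between 12 nM and 85 nM.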

Compound 4, half-maximal inhibitory concentration: 50.1 nM
The estimate for compound 4 lay 1.6-fold (0.19 log units) below the measured number, within the range that was stated.
By their numbers in this assay, from the lowest: compounds 3, 2, 4 and 1 (each within the scatter of the next, the first and the last beyond it).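

In this assay, pyridin-3-yl in place of pyridin-2-yl on the saturated chain carbon bound to the amide-type nitrogen gives a 2.0-fold higher number from compound 3 to compound 4 (0.30 log units; within the scatter), so this change cannot be told from the scatter. (Pyridin-3-yl)methyl in place of phenyl on the amide-type nitrogen likewise gives only a 1.3-fold higher number from compound 2 to compound 4 (0.10 log units; within the scatter), while the step from the methyl group gives a 2.0-fold lower number from compound 1 to compound 4 (0.30 log units; within the scatter), unlike a 2.5-fold lower number from compound 1 to compound 2 (0.40 log units; beyond the scatter) and a 4.0-fold lower number from compound 1 to compound 3 (0.60 log units; beyond the scatter), so not every larger group on this nitrogen clears the scatter relative to compound 1. Nothing measured here accounts for these steps.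

The compounds shown leave open whether pyridin-4-yl on that chain carbon would stand apart from these values in this assay. They also leave open what a longer chain, such as 2-(pyridin-2-yl)ethyl, or a carboxylic acid on the ring would do at this position.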